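The compounds below may be only part of what the source reports. "The series", "measured", "known", "first", "only" and "open" are said of these compounds alone.

In a toxicity assay on HUVEC cells (Homo sapiens) for inhibition (on this read-out higher numbers stand for weaker inhibition of growth and lower numbers for stronger inhibition of growth), compound 1 `C=CCOC(=O)c1ccsc1NC(=O)[C@@H]1CCCN1` gives 149 ug/mL and compound 2 `O=C1CC[C@@H](COC(=O)c2ccsc2NC(=O)[C@@H]2CCCN2)N1` gives 88.6 ug/mL. Going by the values given here, compound 2 thus stands beside compound 1, the only other number, within the scatter, since the single measured step, a 1.7-fold lower number from compound 1 to compound 2 (0.23 log units; within the scatter), is small. Compound 3 `O=C(OC1CCCCC1)c1ccsc1NC(=O)[C@@H]1CCCN1` differs from compound 2 by cyclohexyl in place of (5-oxopyrrolidin-2-yl)methyl on an oxygen next to a carbonyl group. Among the compounds with values here, no measured step involves cyclohexyl in place of (5-oxopyrrolidin-2-yl)methyl, so only that small step from compound 1 to compound 2 bears on it, and the step in this assay is therefore expected to stay within the scatter, with no clear direction, as a 1.1-fold higher number from compound 2 to compound 3 (0.05 log units; within the scatter). Compound 3 is estimated at 100 ug/mL in this assay, within 40 ug/mL to 250 ug/mL.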

Compound 3, concentration for 50% growth inhibition: 137 ug/mL
The estimate for compound 3 lay 1.4-fold (0.14 log units) below the measured number; the range from low to high includes it.
By their numbers in this assay, from the lowest: compounds 2, 3 and 1 (each within the scatter of the next).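

In this assay the exchange of (5-oxopyrrolidin-2-yl)methyl for cyclohexyl on this oxygen gives a 1.5-fold higher number from compound 2 to compound 3 (0.19 log units; within the scatter) and the exchange of allyl for cyclohexyl gives a 1.1-fold lower number from compound 1 to compound 3 (0.04 log units; within the scatter) so this place accepts a carbon-only ring with no step beyond the scatter. Giving up the hydrogen-bond donor and acceptor of (5-oxopyrrolidin-2-yl)methyl therefore leaves the number within the scatter here. Nothing available gives a reason for these values. On these data alone, whether an amine or a carboxylic acid on this oxygen would move the number beyond the scatter remains open.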